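The source may report more compounds than this note shows. Statements on the series, on what has been measured and on what is new or still open speak of the compounds shown alone.

Measured so far in a functional assay on HEK293 cells for agonist activity at D(4) dopamine receptor (Homo sapiens), read by FLIPR; on this read-out lower numbers stand for an effect already at smaller amounts and higher numbers for an effect only at larger amounts of compound:

- compound 1, `O=C(CN1CCC(c2cccc[n+]2[O-])CC1)Nc1cccc(F)c1`: 160 nM
- compound 2, `O=C(CN1CCC(c2cccc[n+]2[O-])CC1)Nc1cccc(C(F)(F)F)c1`: 76 nM

Compound 2 holds the lowest of the two numbers in this assay. For the measured compounds named here, its only neighbour is compound 1, and the one step, a 2.1-fold lower number from compound 1 to compound 2 (0.32 log units; beyond the scatter), is modest but beyond the scatter.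

Compound 3, `O=C(CN1CCC(c2cccc[n+]2[O-])CC1)Nc1cccc(OC(F)(F)F)c1`, is the next compound to be measured. The change from compound 2 is trifluoromethoxy in place of trifluoromethyl on an aromatic carbon. Going by the values given here, no measured step exchanges trifluoromethyl for trifluoromethoxy; the single step available, a 2.1-fold lower number from compound 1 to compound 2 (0.32 log units; beyond the scatter), concerns a different exchange at the same place and therefore bears on the new compound only loosely. Both groups entering in that step and in this one are of similar bulk, so the step of a 1.1-fold higher number from compound 2 to compound 3 (0.05 log units; within the scatter) is expected to stay small, with no clear direction beyond the scatter. Compound 3 is accordingly estimated at 85 nM in this assay, with a range from 30 nM to 250 nM, the width reflecting the absence of any directly comparable step.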

Compound 3, half-maximal effective concentration: 135 nM
Compound 3: the middle estimate sits 1.6-fold (0.20 log units) below what was measured; the measured number falls inside the stated range.
By their numbers in this assay, from the lowest: compounds 2, 3 and 1 (each within the scatter of the next, the first and the last beyond it).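

In this assay, for the compounds shown here, the exchange of trifluoromethyl for trifluoromethoxy gives a 1.8-fold higher number from compound 2 to compound 3 (0.25 log units; within the scatter) and the exchange of fluoro for trifluoromethoxy gives a 1.2-fold lower number from compound 1 to compound 3 (0.07 log units; within the scatter) so compound 3 cannot be separated from either of the other two, even though a 2.1-fold lower number from compound 1 to compound 2 (0.32 log units; beyond the scatter) remains the one step that clears the scatter. On this aromatic carbon, meta to a large group, the series therefore accepts trifluoromethoxy, with its oxygen and its one counted hydrogen-bond acceptor, without a readable step against trifluoromethyl or fluoro, and the three compounds do not form a clear order by group. Nothing available bears on why these steps are as small as they are.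

Open is whether this tolerance extends to groups of a different kind at the same place, such as methoxy, an amine or a carboxylic acid, since all three groups shown carry fluorine. Also open, from the compounds shown here alone, is whether trifluoromethoxy or trifluoromethyl would behave the same way at another carbon of this aromatic ring, and how the maximal effect compares across the series, which a half-maximal concentration alone does not tell.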